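The source may hold more compounds than are shown below. What is called first, only, known or untested is meant among the compounds shown, and "the series" means these compounds.

The measured compounds and their values:

Compound 1 `O=C(O)CC/C=C\CC1COC(c2ccsc2)OC1c1cccnc1` gives 500 nM in an assay for inhibition of Thromboxane-A synthase (Homo sapiens), using microsomes; on this read-out lower numbers stand for stronger inhibition and higher numbers for weaker inhibition.
Compound 2 `COc1ccc(OC(C)(C)C2OCC(C/C=C\CCC(=O)O)C(c3cccnc3)O2)cc1` gives 41 nM in this assay.
Compound 3 `CC(C)(Oc1ccc(F)cc1[N+](=O)[O-])C1OCC(C/C=C\CCC(=O)O)C(c2cccnc2)O1` gives 20 nM in this assay.

Compound 1 stands highest of these three numbers, which on this read-out means it is the weakest inhibitor of the set; both compound 2 and compound 3 lie well below it, beyond the usual scatter.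

Compound 4 `CC(C)(Cc1ccccc1)C1OCC(C/C=C\CCC(=O)O)C(c2cccnc2)O1` has not yet been measured. It differs from compound 1 in a single place: 1-benzyl-1-methylethyl in place of thiophen-3-yl on a saturated ring carbon. Compound 2 and compound 3 also lack the thiophen-3-yl group of compound 1, carrying larger carbon-rich groups instead, and both give far lower numbers than compound 1.

Within the data shown here, the only measured step is a 2.1-fold lower number from compound 2 to compound 3 (0.31 log units; beyond the scatter). That step exchanges one aryl group on an oxygen for another and does not touch the place altered in compound 4, so it offers little direct guidance. Even so, the values of compound 2 and compound 3 suggest that replacing thiophen-3-yl with a bulkier group goes together with a lower number in this assay.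

Compound 4 is therefore expected to give about 60 nM, most likely between 20 nM and 200 nM. This expectation corresponds to an 8.3-fold lower number from compound 1 to compound 4 (0.92 log units; beyond the scatter).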

Compound 4, half-maximal inhibitory concentration: 12 nM
Compound 4: the middle estimate sits 5.0-fold (0.70 log units) above what was measured; the measured number lies below the stated range.
By their numbers in this assay, from the lowest: compounds 4 and 3 (each within the scatter of the next); then compound 2; then compound 1.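

In this assay, among these compounds, the single exchange of thiophen-3-yl for 1-benzyl-1-methylethyl on the saturated ring carbon between two ring oxygen atoms gives a 42-fold lower number from compound 1 to compound 4 (1.62 log units; beyond the scatter), the first direct sign that this position responds strongly to what it carries. The large group itself also tolerates change on its saturated chain carbon: benzyl in place of 4-methoxyphenoxy gives a 3.4-fold lower number from compound 2 to compound 4 (0.53 log units; beyond the scatter), so the carbon-only group of compound 4 outperforms this oxygen-linked aryl group. Against the group of 11 heavy atoms in compound 3, the group of 7 heavy atoms in compound 4 gives a 1.7-fold lower number from compound 3 to compound 4 (0.22 log units; within the scatter), so these two compounds cannot be told apart, and the nitrogen, oxygen and fluorine atoms of the larger group are not required for a number this low.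

Nothing given here explains why these steps have the sizes they do. From the compounds shown here alone, it also remains open whether the benzene ring of the benzyl group matters at all, as a tert-butyl or cyclohexylmethyl group at the same place would show, and whether a plain phenyl group directly on the ring carbon would behave like thiophen-3-yl or like the larger groups.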